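Chloro in place of methyl: compound 2 to compound 3

A few compounds are considered here, and "the series" means these few. Any claim that something is new, unique, unknown or untested is made for them only; others in the source may bear on it.

Of the compounds shown here, two of the shared core have been measured. Compound 1 `O=C(/C=C/c1ccc(O)c(O)c1)NC1CCCCC1` gives 23% in an ADME assay on B16 cells (Mus musculus) for cytotoxicity, read by MTT assay, tested at 10 uM; on this read-out lower numbers stand for a weaker effect and higher numbers for a stronger effect at the one concentration tested. Compound 2 `Cc1cccc(CNC(=O)/C=C/c2ccc(O)c(O)c2)c1` gives 20% in this assay. The two numbers sit within the usual scatter of each other, so on this read-out compound 2 and compound 1 cannot be told apart, and neither can be called the stronger or the weaker.

Compound 3 `O=C(/C=C/c1ccc(O)c(O)c1)NCc1cccc(Cl)c1` is the next member and has not yet been measured. It differs from compound 2 in one place: chloro in place of methyl on an aromatic carbon. One heavy atom leaves and one heavy atom enters, with no ring, no change in hydrogen-bond donors or acceptors and no net charge, on the aromatic carbon meta to a large group; read one bond further out, 3-methylphenyl becomes 3-chlorophenyl.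

Going by the values given here, no step between measured compounds covers such an exchange, so there is nothing to point in either direction. The expectation for the step from compound 2 to compound 3 is therefore no change beyond the scatter, a number 2 percentage points higher from compound 2 to compound 3 (within the scatter). Compound 3 is accordingly estimated at 22%, with a range from 10% to 35%.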

Compound 3, a percentage reported as activity, at one concentration (the size of the read-out at that concentration, not a potency): 22%
For compound 3 middle estimate and measured number coincide at the digits printed; the range from low to high includes it.
By their numbers in this assay, from the lowest: compounds 2, 3 and 1 (each within the scatter of the next).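

In this assay, chloro in place of methyl on an aromatic carbon gives a number 2 percentage points higher from compound 2 to compound 3 (within the scatter), so on this read-out compound 2 and compound 3 cannot be told apart. Going by these compounds alone, this is the first exchange made at a single place, and it shows that the read-out at this position tolerates 3-chlorophenyl in place of 3-methylphenyl without a difference that can be separated from the scatter. Within the data shown here, the finding covers this one pair, at the one concentration tested, and gives no potency for either compound. No measurement bearing on why the two compounds read alike is available.

The compounds shown leave open whether an amine, a carboxylic acid or a methoxy group on the same aromatic carbon would stay within the scatter of compound 2, or whether only exchanges of one heavy atom such as this one do so. Also open, on these data alone, is whether chloro on another aromatic carbon of the ring, or a longer chain carrying the 3-chlorophenyl group on the amide nitrogen, would move the read-out beyond the scatter of compound 3.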